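This account rests on a few compounds, and the source may have more. Where it says the series, first, only, none or still open, it means among the compounds named here.

Measured in a functional assay on SK-MEL cells (Homo sapiens) for cytotoxicity, read by MTT assay, with a stated time of 6 days; a higher number here means that more compound is needed for the effect, a lower number that less compound is needed:
Compound 1 `COc1cc(-c2cc(=O)c3ccc(O)c(O)c3o2)cc(OC)c1OC`: > 25 ug/mL (a limit)
Compound 2 `COc1cc(-c2cc(=O)c3ccc(O)cc3o2)cc(OC)c1O[Si](C)(C)C(C)(C)C`: > 25 ug/mL (a limit)

Compound 2 has no number in this assay. Its result of > 25 ug/mL is a limit of the assay. Compound 1 is no different, with its > 25 ug/mL also a limit. The whole measured set therefore comes down to one entry: the limit of > 25 ug/mL in this assay, at which 2 of the 2 values shown sit. Neither compound can be ranked against the other.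

Compound 3 `COc1cc(-c2cc(=O)c3ccc(O)c(O)c3o2)cc(OC)c1O[Si](C)(C)C(C)(C)C` follows from compound 2 by one change, hydroxy in place of hydrogen on an aromatic carbon, ortho to a hydroxy group. Within the data shown here, no measured pair shows what this change does in this assay, so any forecast is uncertain. With no measured number to start from, no step beyond the scatter is expected, and a further limit is a likely outcome. The estimated step is a number no higher from compound 2 to compound 3 (the limit leaves the size open). For compound 3 the expected value is 25 ug/mL, with an estimated range of 10 ug/mL to 50 ug/mL.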

Compound 3, concentration for half-maximal effect: 0.11 ug/mL
Beside the measured number, compound 3's estimate is 230-fold (2.36 log units) above it; the whole stated range lies above it.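

Set in this assay, hydroxy in place of hydrogen on an aromatic carbon, ortho to a hydroxy group, gives an at least 220-fold lower number from compound 2 to compound 3 (2.35 log units; beyond the scatter), so this position can move the result a long way, which the earlier compounds, both at a limit, could not show. The change on the other side of the molecule counts as well: a group of 7 heavy atoms (6 carbon, 1 silicon) in place of one carbon atom, on an oxygen on an aromatic ring, gives an at least 220-fold lower number from compound 1 to compound 3 (2.35 log units; beyond the scatter). Only compound 3 carries both the added hydroxy group and the silicon group, and each compound with just one of them stays at a limit, so neither change is enough alone among these three compounds: the limit of > 25 ug/mL in this assay, at which 2 of the 3 values shown sit.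

As far as these compounds go, what a methoxy group or an amine would do in place of the new hydroxy group remains open. So does the question of whether a simple longer carbon chain on that oxygen could stand in for the silicon group, and the true size of both steps stays unknown, since each starts from a limit.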